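The source may report more compounds than this note shows. Statements on the series, on what has been measured and on what is new or still open speak of the compounds shown alone.

Measured so far:
- Compound 1 `NC1=NC2(CCSCC2)N(OCCCOc2ccc(Cl)c(Cl)c2)C(N)=N1`: 140 nM
- Compound 2 `NC1=NC2(CCOCC2)N(OCCCOc2ccc(F)cc2)C(N)=N1`: 2380 nM

Both compounds share a core and were tested in a functional assay on HL-60 cells (Homo sapiens) for antiproliferative activity, read by MTT assay, with a stated time of 72 h; on this read-out higher numbers stand for weaker inhibition and lower numbers for stronger inhibition. Of the two numbers, compound 2 stands at the higher end, meaning the weaker inhibition of cell growth. Going by the values given here, its only neighbour is compound 1, whose number is lower, and the gap between them lies beyond the scatter of repeated measurement. The two differ in more than one place, so nothing can be said about which part of the difference matters.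

Compound 3 `Cc1ccc(OCCCON2C(N)=NC(N)=NC23CCOCC3)cc1` has not yet been measured. It differs from compound 2 in a single place: methyl in place of fluoro on an aromatic carbon. Methyl in place of fluoro on an aromatic carbon is a small swap of one heavy atom for another, and no measured pair here shows what such a swap does. With nothing to lean on, the expectation is a step of no more than the usual scatter, in either direction.

Compound 3 is expected to give 2000 nM, within a range from 700 nM to 6000 nM. The expected step is a 1.2-fold lower number from compound 2 to compound 3 (0.08 log units; within the scatter).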

Compound 3, half-maximal inhibitory concentration: 2580 nM
Compound 3: middle estimate off by 1.3-fold (0.11 log units), on the low side, and the stated range covers the measured number.
By their numbers in this assay, from the lowest: compound 1; then compounds 2 and 3 (each within the scatter of the next).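

In this assay, replacing 4-fluorophenyl with 4-methylphenyl gives a 1.1-fold higher number from compound 2 to compound 3 (0.04 log units; within the scatter), so at this place on the aromatic ring, para to a large group, the assay does not tell the two groups apart. Going by these compounds alone, this is the first comparison here in which only one place changes, and it shows that, with the rest of compound 2 held fixed, exchanging fluoro for methyl leaves the antiproliferative read-out within the scatter of repeated measurement. Nothing available gives a reason for this match, such as a measured property of either group.

As far as these compounds go, whether other groups at this place would also leave the number within the scatter remains open: a methoxy group, an amine, a nitrile or a carboxylic acid might behave quite differently from fluoro and methyl. From the compounds shown here alone, compound 1 differs from compound 2 and compound 3 in more than one place, so it also remains open whether the lower number of compound 1, at 140 nM, traces back to its core, its two chloro groups or both together.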